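Bromo for cyano on one aryl arm of the core

A few compounds are considered here, and "the series" means these few. Any claim that something is new, unique, unknown or untested is made for them only; others in the source may bear on it.

Measured compounds:
compound 1, `Brc1ccc(-c2ncc(OCC3CCNCC3)nc2-c2ccc(Br)cc2)cc1`: 5700 nM
compound 2, `N#Cc1ccc(-c2ncc(OCC3CCNCC3)nc2-c2ccc(C#N)cc2)cc1`: > 10000 nM

Compound 1, `Brc1ccc(-c2ncc(OCC3CCNCC3)nc2-c2ccc(Br)cc2)cc1`, carries two bromo-substituted aryl arms on the shared core, and in an assay on isolated protein for inhibition of histone acetyltransferase p300 (Homo sapiens), read by scintillation counting, with stated times of 10 min and 30 min (a higher number here means a weaker inhibitor, a lower number a stronger inhibitor), compound 1 gives 5700 nM. Compound 2, `N#Cc1ccc(-c2ncc(OCC3CCNCC3)nc2-c2ccc(C#N)cc2)cc1`, carries two cyano-substituted arms instead. In this assay compound 2 gives only > 10000 nM, which is a limit of the assay and not a measured number; compound 2 thus stands at the weak end of the values seen so far, as noted in the limit of > 10000 nM in this assay, at which 1 of the 2 values shown sits.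

Compound 3, `N#Cc1ccc(-c2ncc(OCC3CCNCC3)nc2-c2ccc(Br)cc2)cc1`, sits between the two: the change from compound 2 is bromo in place of cyano on an aromatic carbon, leaving the other arm as it is. With compound 1 at 5700 nM, one bromo arm is expected to move the value towards compound 1, so the step of an at least 1.2-fold lower number from compound 2 to compound 3 (0.09 log units; that floor lies within the scatter) is expected to be small and towards stronger inhibition, likely within the usual scatter. Compound 3 is therefore estimated at 8000 nM, with a range from 4000 nM to 20000 nM in this assay.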

Compound 3, half-maximal inhibitory concentration: > 10000 nM
Compound 3 ended at the assay's limit (the forecaster's own chance of this, stated with the estimate: 40%); middle value at least 1.2-fold (0.09 log units) from the limit.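

Compound 3 shows that keeping one bromo arm is not enough to return a readable value in this assay, whereas compound 1, with bromo on both arms, gave a number. Changing a single arm of compound 1 gives an at least 1.7-fold higher number from compound 1 to compound 3 (0.24 log units; that floor lies within the scatter), so the data show a loss of inhibition only as a floor, and that floor cannot be separated from the usual variation between repeated measurements. The other new step, bromo in place of cyano on an aromatic carbon, cannot be read, and compound 3 joins compound 2 at the limit, leaving compound 1 as the only compound with a measured number: the limit of > 10000 nM in this assay, at which 2 of the 3 values shown sit.

The compounds shown leave open how much weaker compound 2 and compound 3 really are than compound 1, and whether the two cyano-bearing compounds differ at all. They also leave open how inhibition would respond if the same place on the aromatic ring carried another group, such as chloro, methoxy, an amine or a carboxylic acid, in place of bromo or cyano.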